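Cyano at the double-bonded ring carbon of compound 2

This account rests on a few compounds, and the source may have more. Where it says the series, first, only, none or still open, it means among the compounds named here.

Going by the values given here, compound 2 `COc1ccc2c(c1)OC(c1cc(OC)c(OC)c(OC)c1)C=C2` stands at the higher end of the two numbers so far: in a functional assay for inhibition of nuclear factor NF-kappa-B complex (Homo sapiens) (a higher number here means a weaker inhibitor, a lower number a stronger inhibitor), compound 2 gives 17700 nM, while compound 1 `CCCC(=O)C1=Cc2ccc(OC)cc2OC1c1cc(OC)c(OC)c(OC)c1` gives 11700 nM, and the two lie within the scatter of each other. Among the compounds with values here, the one measured step, a 1.5-fold higher number from compound 1 to compound 2 (0.18 log units; within the scatter), replaces propylcarbonyl with hydrogen on a double-bonded ring carbon and moves the number very little.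

Compound 3 `COc1ccc2c(c1)OC(c1cc(OC)c(OC)c(OC)c1)C(C#N)=C2` is the next member; it differs from compound 2 by cyano in place of hydrogen on a double-bonded ring carbon. Within the data shown here, the same ring carbon is the site of the one measured step, which bears on the new step directly: a substituent there versus hydrogen gave a difference within the scatter. Among the measured compounds shown here, no other step touches this position, so nothing suggests a large move in either direction.

For compound 3 the expected step in this assay is therefore a 1.5-fold lower number from compound 2 to compound 3 (0.17 log units; within the scatter), small and not beyond the scatter. The estimate for compound 3 in this assay is 12000 nM, with a range of 4000 nM to 36000 nM.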

Compound 3, half-maximal inhibitory concentration: 3400 nM
For compound 3 the middle estimate is 3.5-fold (0.55 log units) above the measured one; the measured number lies below the stated range.
By their numbers in this assay, from the lowest: compound 3; then compounds 1 and 2 (each within the scatter of the next).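

In this assay this double-bonded ring carbon, two ring bonds from the ring oxygen, proves sensitive to what it carries: cyano in place of hydrogen gives a 5.2-fold lower number from compound 2 to compound 3 (0.72 log units; beyond the scatter), a modest step beyond the scatter, whereas propylcarbonyl and hydrogen had stayed within the scatter of each other, at a 1.5-fold higher number from compound 1 to compound 2 (0.18 log units; within the scatter). Cyano also separates from propylcarbonyl at the same carbon, with a 3.4-fold lower number from compound 1 to compound 3 (0.54 log units; beyond the scatter), so the position distinguishes between substituents and not only between a substituent and hydrogen, and compound 3 is the strongest inhibitor of the three, its steps to both others being beyond the scatter. No measurement available here accounts for the difference between cyano and propylcarbonyl at this position.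

The compounds shown leave open whether the lower number is particular to cyano or extends to other groups on this carbon, such as a carboxylic acid, a primary amide, an amine or an acetyl group. They also leave open whether the step from hydrogen to cyano keeps its size when the large group on the ring atom next to this carbon is changed.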